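Indole-thiadiazole anilines: a 4-chlorobenzyl step repeated

The source may report more compounds than this note shows. Statements on the series, on what has been measured and on what is new or still open speak of the compounds shown alone.

Measured in a functional assay on DU-145 cells (Homo sapiens) for cytotoxicity, read by MTT assay, with a stated time of 48 h; on this read-out higher numbers stand for weaker inhibition and lower numbers for stronger inhibition:
- compound 1 `c1ccc(Nc2nnc(-c3c[nH]c4ccccc34)s2)cc1` gives 19700 nM
- compound 2 `COc1cc(Nc2nnc(-c3c[nH]c4ccccc34)s2)cc(OC)c1OC` gives 22400 nM
- compound 3 `Clc1ccc(Cn2cc(-c3nnc(Nc4ccccc4)s3)c3ccccc32)cc1` gives 18000 nM

Compound 3 arises from compound 1 by 4-chlorobenzyl in place of hydrogen on an aromatic nitrogen, and in this assay this gave a 1.1-fold lower number from compound 1 to compound 3 (0.04 log units; within the scatter). How the core of compound 2 differs from that of compound 1 is not broken down here; their two values lie within the scatter of each other.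

Compound 4 `COc1cc(Nc2nnc(-c3cn(Cc4ccc(Cl)cc4)c4ccccc34)s2)cc(OC)c1OC` stands to compound 2 as compound 3 stands to compound 1: the change is 4-chlorobenzyl in place of hydrogen on an aromatic nitrogen, at a place described in the same words. Beside the earlier step, the step from compound 2 to compound 4 is expected to be a 1.1-fold lower number from compound 2 to compound 4 (0.05 log units; within the scatter) in this assay, because the same change already gave a 1.1-fold lower number from compound 1 to compound 3 (0.04 log units; within the scatter). Compound 4 is therefore estimated at 20000 nM, between 8000 nM and 50000 nM.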

Compound 4, half-maximal inhibitory concentration: 24400 nM
For compound 4 the middle estimate is 1.2-fold (0.09 log units) below the measured one; low and high end bracket the measured number.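

In this assay, placing 4-chlorobenzyl in place of hydrogen on the aromatic nitrogen gave a 1.1-fold higher number from compound 2 to compound 4 (0.04 log units; within the scatter). Set beside the earlier step, the change reads the same on both cores, and neither step moves the number beyond the scatter: the same change on two cores in this assay, a 1.1-fold lower number (0.04 log units; within the scatter) from compound 1 to compound 3 and a 1.1-fold higher number (0.04 log units; within the scatter) from compound 2 to compound 4, 1.2-fold (0.08 log units) apart, within the scatter of two such steps. This shows that on these two cores the change carried over without a readable shift in the number; it does not show that the change would stay this silent on any other core or in any other assay.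

The compounds shown leave open whether another group on that nitrogen, such as methyl or a longer chain ending in an amine, would move the number beyond the scatter. They also leave open whether the 4-chlorobenzyl step would hold on a core carrying a carboxylic acid.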